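The compounds below may be only part of what the source reports. "The series", "measured", "known", "first", "only" and "open" are said of these compounds alone.

Measured compounds:
compound 1, `COc1ccc2[nH]c(=O)c(-c3nc4ccccc4[nH]3)cc2c1` — > 100000 nM
compound 2, `COc1ccc2[nH]c(=O)c(-c3nc4cc(C)c(C)cc4[nH]3)cc2c1` — > 100000 nM
compound 3, `O=c1[nH]c2ccccc2cc1-c1nc2cc(Cl)ccc2[nH]1` — 10500 nM

In a functional assay on SK-OV-3 cells (Homo sapiens) for cytotoxicity, read by MTT assay, with a stated time of 48 h (a higher number here means a weaker inhibitor, a lower number a stronger inhibitor), compound 1 gives only a limit, > 100000 nM, not a number. Compound 2 likewise reaches only a limit, > 100000 nM. Compound 3 gives a number in this assay, 10500 nM. Compound 1 therefore stands at the limit of > 100000 nM in this assay, at which 2 of the 3 values shown sit, with no measured value of its own. Compound 4, `COc1ccc2[nH]c(=O)c(-c3nc4cc([N+](=O)[O-])ccc4[nH]3)cc2c1`, differs from compound 1 by nitro in place of hydrogen on an aromatic carbon. For the measured compounds named here, no step between measured compounds is recorded, so the size of the step from compound 1 to compound 4 rests on expectation alone. Compound 4 is expected to give a value around 60000 nM, within 10000 nM to 100000 nM, which would mean an expected step of an at least 1.6-fold lower number from compound 1 to compound 4 (0.22 log units; that floor lies within the scatter) toward stronger inhibition, though a further limit remains quite possible.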

Compound 4, half-maximal inhibitory concentration: > 100000 nM
Compound 4 gave a limit, no number; the forecaster's own chance of this, stated with the estimate: 50%; at least 1.6-fold (0.22 log units) between middle value and limit.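

In this assay compound 4 gives > 100000 nM, a limit and not a number. With compound 1 also at a limit, no step between compound 1 and compound 4 can be read: the limit of > 100000 nM in this assay, at which 3 of the 4 values shown sit. The compounds shown leave open whether nitro in place of hydrogen on an aromatic carbon changes the value at all.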